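This account rests on a few compounds, and the source may have more. Where it says the series, first, only, none or still open, it means among the compounds named here.

Among the compounds with values here, compound 2 `CC[C@H](C)[C@H](N)CN(C(=O)[C@@H]1C[C@H]1c1ccc(Cl)cc1)c1ccc(-c2ccccc2)cc1` and compound 1 `CO[C@H](C)[C@H](N)CN(C(=O)[C@@H]1C[C@H]1c1ccccc1)c1ccc(-c2ccccc2)cc1` are the two compounds with numbers so far. In a functional assay for agonist activity at G protein-coupled receptor 88 (Homo sapiens), read by HTRF and cAMP accumulation (on this read-out lower numbers stand for an effect already at smaller amounts and higher numbers for an effect only at larger amounts of compound), compound 1 gives 0.68 nM, while compound 2 gives 4300 nM, the higher of the two numbers and far beyond the scatter apart from compound 1. Within the data shown here, the two differ in more than one place, so no single step between them can be read off; only the two values themselves can be compared.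

Compound 3 `CC[C@H](C)[C@H](N)CN(C(=O)[C@@H]1C[C@H]1c1ccccc1F)c1ccc(-c2ccccc2)cc1` is the next compound to be tested. It differs from compound 2 in one place: 2-fluorophenyl in place of 4-chlorophenyl on a saturated ring carbon, a 2-fluorophenyl in place of 4-chlorophenyl on a saturated ring carbon of the three-membered ring, so that 2-(4-chlorophenyl)cyclopropyl becomes 2-(2-fluorophenyl)cyclopropyl. Among the measured compounds shown here, no measured pair shows this kind of exchange, so the direction of the step rests on judgement alone. Given that compound 1 with an unsubstituted phenyl gives 0.68 nM, some recovery toward lower numbers is expected, but a modest one. The expected step is a 4.3-fold lower number from compound 2 to compound 3 (0.63 log units; beyond the scatter) in this assay. Compound 3 is estimated to give 1000 nM, within a range from 100 nM to 10000 nM.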

Compound 3, half-maximal effective concentration: 650 nM
The estimate for compound 3 lay 1.5-fold (0.19 log units) above the measured number; low and high end bracket the measured number.
By their numbers in this assay, from the lowest: compound 1; then compound 3; then compound 2.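

Within the data shown here, with the first step that can be read from a single change, the phenyl group on the three-membered ring proves to be a place where substitution alters the read-out: in this assay, 2-fluorophenyl in place of 4-chlorophenyl gives a 6.6-fold lower number from compound 2 to compound 3 (0.82 log units; beyond the scatter). The step is modest but beyond the scatter, and compound 3, at 650 nM, shows that this position tolerates a change of both the halogen and its location on the phenyl ring without a loss in this assay. Nothing available explains the size or direction of this step.

The compounds shown leave open whether the halogen or its location accounts for the step, a question that 4-fluorophenyl or 2-chlorophenyl on the same core would address. Among these compounds, they also leave open how much of the low number of compound 1, at 0.68 nM, belongs to its unsubstituted phenyl and how much to the other place in which it differs, and no step between compound 1 and either of the other compounds can be read.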